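Notes on the hydroxyethyl analogue, compound 4

The source may report more compounds than this note shows. Statements on the series, on what has been measured and on what is new or still open speak of the compounds shown alone.

Measured so far in an assay for inhibition of 15-hydroxyprostaglandin dehydrogenase [NAD(+)] (Homo sapiens), read by fluorescence, with a stated time of 15 min, in the presence of a further agent that is not named here; on this read-out lower numbers stand for stronger inhibition and higher numbers for weaker inhibition:
compound 1 `CCCC[S+]([O-])c1sc2nc(-c3nccs3)cc(-c3ccc(C(=O)OC)cc3)c2c1N` gives 15.1 nM
compound 2 `CCCC[S+]([O-])c1nc2ccc(-c3cccs3)nc2s1` gives 1230 nM
compound 3 `CCCC[S+]([O-])c1sc2nc(-c3nccs3)cc(-c3ccc(C(=O)N(C)C)cc3)c2c1N` gives 5.9 nM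

Compound 3 has the lowest number of the three; compound 1 stands nearest, and compound 2, built on a different core, lies far away. Within the data shown here, the one single-place step in the set is a 2.6-fold lower number from compound 1 to compound 3 (0.41 log units; beyond the scatter), a dimethylamino in place of methoxy on a carbonyl carbon.

Compound 4 `CCCC[S+]([O-])c1sc2nc(-c3nccs3)cc(-c3ccc(CCO)cc3)c2c1N` differs from compound 3 by 2-hydroxyethyl in place of dimethylcarbamoyl on an aromatic carbon. Among the measured compounds shown here, no measured step exchanges a dimethylcarbamoyl for a 2-hydroxyethyl; the step from compound 1 to compound 3 only shows that changing the group on this aromatic carbon, para to a large group, moves the number modestly. Compound 2 is no guide here, since it differs in several places.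

For compound 4 the expectation is therefore a small step in this assay, if any, most likely toward a somewhat higher number, as a step of a 2.0-fold higher number from compound 3 to compound 4 (0.31 log units; beyond the scatter). The estimate for compound 4 in this assay is 12 nM, with a range from 4 nM to 40 nM.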

Compound 4, half-maximal inhibitory concentration: 2.9 nM
The estimate for compound 4 lay 4.1-fold (0.62 log units) above the measured number; measured number below the stated range.
By their numbers in this assay, from the lowest: compound 4; then compound 3; then compound 1; then compound 2.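

In this assay, the aromatic carbon para to a large group does not need a carbonyl-bearing group for a low number: there is a 2.0-fold lower number from compound 3 to compound 4 (0.31 log units; beyond the scatter), and a 5.2-fold lower number from compound 1 to compound 4 (0.72 log units; beyond the scatter). With compound 4, three different groups have now been compared at this place, and the one without a carbonyl gives the lowest number, although its step from compound 3 is modest. The 2-hydroxyethyl has fewer heavy atoms than dimethylcarbamoyl and adds a hydrogen-bond donor, but these differences arrive together in one step, and nothing available explains the lower number.

Still open, going by these compounds, is whether the hydroxyl or the chain carries the step. A plain ethyl, a 2-aminoethyl or a longer chain such as 3-hydroxypropyl on this carbon would help separate the two.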